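Series notes: arylidene thiazolone esters, aryl exchange at the exocyclic carbon

The source may hold more compounds than are shown below. What is called first, only, known or untested is meant among the compounds shown, and "the series" means these compounds.

Measured in a functional assay on K562 cells (Homo sapiens) for inhibition, read by MTT assay, with a stated time of 72 h; a lower number here means a stronger inhibitor, a higher number a weaker inhibitor:
- compound 1 `CCOC(=O)C1=C(Nc2ccccc2)S/C(=C\c2ccccc2O)C1=O`: 8800 nM
- compound 2 `CCOC(=O)C1=C(Nc2cccc([N+](=O)[O-])c2)S/C(=C\c2ccc[nH]2)C1=O`: 7200 nM
- compound 3 `CCOC(=O)C1=C(Nc2ccccc2)S/C(=C\c2ccc(C(=O)OCC)[nH]2)C1=O`: 46800 nM

Compound 1 holds the second highest of the three numbers in this assay. Its nearest neighbour is compound 2, whose number lies within the scatter of that of compound 1, so the two cannot be told apart. Compound 3 stands furthest away, with a number clearly higher than that of compound 1, beyond the scatter.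

Compound 4 `CCOC(=O)C1=C(Nc2ccccc2)S/C(=C\c2cc3cccnc3[nH]2)C1=O` has not been measured. Relative to compound 1 the change is a group of 9 heavy atoms (7 carbon, 2 nitrogen; one five-membered aromatic ring with 1 hetero atom, one six-membered aromatic ring with 1 hetero atom) in place of a group of 7 heavy atoms (6 carbon, 1 oxygen; one six-membered aromatic ring of carbon only), on a double-bonded chain carbon bound to a double-bonded ring carbon. For the measured compounds named here, no measured pair in this set isolates such an exchange, so no step can be read directly; the values of compound 1 and compound 2 show that two different aryl groups at this position give numbers within the scatter of each other, while compound 3 shows that a further substituent on the five-membered ring can push the number well upward.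

On that basis compound 4 is expected to land close to compound 1, with a step of a 1.3-fold lower number from compound 1 to compound 4 (0.10 log units; within the scatter), likely within the scatter. The estimate for compound 4 in this assay is 7000 nM, with a range from 2500 nM to 20000 nM.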

Compound 4, half-maximal inhibitory concentration: > 100000 nM
Compound 4: a limit, no number (the forecaster's own chance of this, stated with the estimate: 5%); middle value at least 14-fold (1.15 log units) away from the limit.
By their numbers in this assay, from the lowest: compounds 2 and 1 (each within the scatter of the next); then compound 3. At a limit, above all of these: compound 4.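

In this assay compound 4 gives a limit of the assay and not a number: the limit of > 100000 nM in this assay, at which 1 of the 4 values shown sits. The exchange of 2-hydroxyphenyl for the group of a five-membered and a six-membered aromatic ring, each with 1 hetero atom, gives an at least 11-fold higher number from compound 1 to compound 4 (1.05 log units; beyond the scatter), so this place on the double-bonded chain carbon does not accept every aromatic group. The earlier compounds shown here gave numbers throughout, even compound 3 at 46800 nM, while compound 4 shows that an exchange at this place alone, with the rest of the core of compound 1 unchanged, can take the value out of the measurable range.

The compounds shown leave open whether the ring nitrogen of the six-membered ring or the second ring itself goes with this large step; an indolyl group would separate the two. Also open, on these data alone, is whether a plain phenyl or a 2-aminophenyl group at this place keeps the value of compound 1.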